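This account rests on a few compounds, and the source may have more. Where it says the series, first, only, none or still open, it means among the compounds named here.

Working notes on the series. The read-out throughout is a functional assay on MCF7 cells (Homo sapiens) for inhibition, read by MTT assay, with a stated time of 72 h; on this read-out higher numbers stand for weaker inhibition and lower numbers for stronger inhibition. Compound 1 `Cc1cc(Nc2cc(-c3ccccc3)[nH]n2)n2nc(SCC3CCCCC3)nc2n1` is the starting point; in this assay compound 1 gives only a limit, > 50000 nM, so no number stands for it. Within the data shown here, the one numerical value in the set is that of compound 2 `CCCCCc1c(C)nc2nc(SCc3ccc(Cl)cc3)nn2c1Nc1cc(-c2ccccc2)[nH]n1`, which in this assay gives 6390 nM; compound 2 differs from compound 1 in more than one place, so the two values can only be set side by side, not read as a single step. The limit for compound 1 is recorded as the limit of > 50000 nM in this assay, at which 1 of the 2 values shown sits. The step to compound 3 `Cc1cc(Nc2cc(-c3ccccc3)[nH]n2)n2nc(SCc3cccc4ccccc34)nc2n1` is a single change, (naphthalen-1-yl in place of cyclohexyl on a saturated chain carbon bound to a sulfur). Among the measured compounds shown here, with no measured step of this kind to lean on, the expected size of the move from compound 1 to compound 3 is uncertain and is estimated as an at least 2.5-fold lower number from compound 1 to compound 3 (0.39 log units; beyond the scatter), in the direction of stronger inhibition. Compound 3 is expected to give 20000 nM, with a range of 5000 nM to 60000 nM.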

Compound 3, half-maximal inhibitory concentration: 7560 nM
Compound 3: middle estimate off by 2.6-fold (0.42 log units), on the high side, within the range that was stated.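

In this assay, among these compounds, naphthalen-1-yl in place of cyclohexyl on a saturated chain carbon bound to a sulfur gives an at least 6.6-fold lower number from compound 1 to compound 3 (0.82 log units; beyond the scatter), the one step that can be read. With everything else in the core of compound 1 unchanged, this place alone separates a limit from a measured value, so the group carried there matters to the read-out. The size of the step has only a lower bound, and compound 1 is a limit, not a number: the limit of > 50000 nM in this assay, at which 1 of the 3 values shown sits.

As far as these compounds go, whether the change needs both aromatic rings of naphthalen-1-yl, or whether a plain phenyl or a straight hexyl chain in the same place would serve, remains open. Compound 2 differs from the others in more than one place, so any steps involving it cannot be read.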